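From Compound 3 to Compound 4: Changing the Aryl Group

The source may report more compounds than this note shows. Statements on the series, on what has been measured and on what is new or still open speak of the compounds shown alone.

In a functional assay on HeLa cells (Homo sapiens) for antiproliferative activity, read by sulforhodamine B assay, with a stated time of 72 h (on this read-out higher numbers stand for weaker inhibition and lower numbers for stronger inhibition), compound 1 (`COc1ccccc1NC(=S)N/N=C/c1ccc2ccccc2n1`) reads > 100000 nM as a limit of the assay and not a number. Compound 2 (`Fc1ccccc1NC(=S)N/N=C/c1ccc2ccccc2n1`) reads > 100000 nM as a limit of the assay too. Among the measured compounds shown here, compound 3 (`COc1cccc(NC(=S)N/N=C/c2ccc3ccccc3n2)c1`) gives 74500 nM as the only true number in the set. Set beside compound 3 is the limit of > 100000 nM in this assay, at which 2 of the 3 values shown sit, and nothing more.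

Compound 4 (`S=C(N/N=C/c1ccc2ccccc2n1)Nc1ccc(Br)cc1`) carries 4-bromophenyl in place of 3-methoxyphenyl on an amide-type nitrogen. Two measured steps change the group at that nitrogen: an at least 1.3-fold lower number from compound 1 to compound 3 (0.12 log units; that floor lies within the scatter) and also an at least 1.3-fold lower number from compound 2 to compound 3 (0.12 log units; that floor lies within the scatter) and both are floors within the scatter. The remaining step, a step that the two limits leave unreadable from compound 1 to compound 2, gives no size. For the measured compounds named here, no measured compound carries 4-bromophenyl, so the data support no firm direction. The expectation therefore stays anchored on compound 3 at 74500 nM in the absence of a closer comparison. The expected step is a 1.5-fold lower number from compound 3 to compound 4 (0.17 log units; within the scatter) and no move beyond the scatter is anticipated. For compound 4 the estimated value is 50000 nM with an expected range from 10000 nM to 100000 nM and a reading at the limit of the assay remains possible.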

Compound 4, half-maximal inhibitory concentration: 56800 nM
Beside the measured number, compound 4's estimate is 1.1-fold (0.06 log units) below it; measured number inside the range.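

In this assay, among the compounds shown here, the new result gives the first step at the amide-type nitrogen between two true numbers: a 1.3-fold lower number from compound 3 to compound 4 (0.12 log units; within the scatter). On this read-out, 4-bromophenyl and 3-methoxyphenyl therefore cannot be told apart, and the steps against the two compounds held at a limit, an at least 1.7-fold lower number from compound 2 to compound 4 (0.24 log units; that floor lies within the scatter) and an at least 1.7-fold lower number from compound 1 to compound 4 (0.24 log units; that floor lies within the scatter), add only floors that stay within the scatter. The two true numbers come with 3-methoxyphenyl and 4-bromophenyl, while compound 1 with 2-methoxyphenyl and compound 2 with 2-fluorophenyl stay at a limit and not a number, a split that these floors do not confirm: the limit of > 100000 nM in this assay, at which 2 of the 4 values shown sit.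

As far as these compounds go, it remains open whether any group at this nitrogen can move the number beyond the scatter, and the step between the two compounds held at a limit cannot be read. Also open, from the compounds shown here alone, is what a 4-aminophenyl group, a 4-carboxyphenyl group or a longer alkyl chain in place of the aryl group would give on the shared core.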